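Inverting the second stereocentre of an azido phospholipid inhibitor

This account rests on a few compounds, and the source may have more. Where it says the series, first, only, none or still open, it means among the compounds named here.

Measured compounds:
compound 1, `CCCCCCCCCCCCCCC[C@H](O)[C@H](COP(=O)(O)O)N=[N+]=[N-]`, 16400 nM
compound 2, `CCCCCCCCCCCCCCC[C@H](O)[C@@H](COP(=O)(O)O)N=[N+]=[N-]`, 6300 nM

Both compounds were examined in an assay on isolated protein for inhibition of sphingosine-1-phosphate lyase 1 (Homo sapiens), using Lineweaver-Burk analysis; a higher number here means a weaker inhibitor, a lower number a stronger inhibitor. Compound 1 gives 16400 nM, while compound 2 gives 6300 nM, so compound 2 stands with the lowest number of the two, separated from compound 1 by a 2.6-fold lower number from compound 1 to compound 2 (0.42 log units; beyond the scatter). The only difference between them is a single stereocentre at a saturated chain carbon, and the evidence bearing on that step is the fact that one of compounds 1 and 2 is drawn with a defined configuration and the other without, at the place where they differ.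

Compound 3, `CCCCCCCCCCCCCCC[C@@H](O)[C@@H](COP(=O)(O)O)N=[N+]=[N-]`, has not been measured. It differs from compound 2 by the two compounds have the same atoms and bonds; at least one stereo element is drawn with a configuration in one of them and without one in the other: 1 of 3 stereo elements differ; a stereocentre at a saturated chain carbon is drawn S in compound 2 and R in compound 3; nothing leaves and nothing enters. Within the data shown here, the one measured step that bears on this change, a 2.6-fold lower number from compound 1 to compound 2 (0.42 log units; beyond the scatter), concerns the other chain stereocentre and was modest. Since the stereocentre now inverted is a different one, the expectation is a step of similar or smaller size, most likely toward a somewhat higher number, estimated as a 1.6-fold higher number from compound 2 to compound 3 (0.20 log units; within the scatter). Compound 3 is therefore expected to give about 10000 nM in this assay, within a range of 3000 nM to 35000 nM.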

Compound 3, inhibition constant: 36700 nM
For compound 3 the middle estimate is 3.7-fold (0.56 log units) below the measured one; measured number outside the range, above it.
By their numbers in this assay, from the lowest: compound 2; then compound 1; then compound 3.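

In this assay, the newly inverted stereocentre proves sensitive to configuration, with a 5.8-fold higher number from compound 2 to compound 3 (0.77 log units; beyond the scatter), and this step runs in the opposite direction to a 2.6-fold lower number from compound 1 to compound 2 (0.42 log units; beyond the scatter) at the other chain stereocentre. With both stereocentres inverted, the net change is a 2.2-fold higher number from compound 1 to compound 3 (0.35 log units; beyond the scatter), and compound 2 stands as the strongest inhibitor of the three, its steps to both others being beyond the scatter. The only evidence bearing on the new single-centre step is the difference in how the two compounds are drawn: the fact that one of compounds 2 and 3 is drawn with a defined configuration and the other without, at the place where they differ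

The compounds shown leave open how the fourth combination of the two configurations would stand in this assay, and therefore whether the effect of inverting one stereocentre depends on the configuration of the other. They also leave open whether the same order of stereoisomers would hold if an amine took the place of the azide or a carboxylic acid took the place of the phosphate, and they give no account of why these configurations differ.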